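Compound 2 and the Step to Compound 3

The compounds below may be only part of what the source reports. "The series", "measured", "known", "first", "only" and "open" are said of these compounds alone.

Among the measured compounds shown here, in a functional assay on CCRF-CEM cells (Homo sapiens) for antiproliferative activity, read by cell counting, with a stated time of 96 h (a lower number here means a stronger inhibitor, a higher number a weaker inhibitor), compound 1 (`COc1ccc(Oc2ccccc2NC(C)=C2C(=O)CC(c3ccccc3)CC2=O)cc1`) gives 120 nM and compound 2 (`COc1cc(Oc2ccccc2NC(C)=C2C(=O)CC(c3ccccc3)CC2=O)ccc1N`) gives 12 nM, the lower of the two numbers so far. Compound 3 (`CC(Nc1ccccc1Oc1ccc(C(C)O)cc1)=C1C(=O)CC(c2ccccc2)CC1=O`) has 4-(1-hydroxyethyl)phenyl in place of 4-amino-3-methoxyphenyl, on an oxygen on an aromatic ring: 4-(1-hydroxyethyl)phenyl in place of 4-amino-3-methoxyphenyl on an oxygen on an aromatic ring. For the measured compounds named here, only one measured step bears on this change. That step, a 10-fold lower number from compound 1 to compound 2 (1.00 log units; beyond the scatter), put 4-amino-3-methoxyphenyl in place of 4-methoxyphenyl at the same place. Going by the values given here, compound 3, like compound 1, lacks the 4-amino-3-methoxyphenyl group, while no measured compound carries 4-(1-hydroxyethyl)phenyl. Going by compound 2 and the size of a 10-fold lower number from compound 1 to compound 2 (1.00 log units; beyond the scatter), a move back toward a higher number is expected, somewhat smaller than that step. In this assay, the expected change is a 5.8-fold higher number from compound 2 to compound 3 (0.77 log units; beyond the scatter). For compound 3 the estimate is 70 nM, with an expected range of 15 nM to 300 nM.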

Compound 3, half-maximal inhibitory concentration: 120 nM
Compound 3: the middle estimate sits 1.7-fold (0.23 log units) below what was measured; low and high end bracket the measured number.
By their numbers in this assay, from the lowest: compound 2; then compounds 1 and 3 (each within the scatter of the next).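

At this place, on an oxygen on an aromatic ring, the low number of compound 2 does not carry over to another group of the same heavy-atom count: in this assay, 4-(1-hydroxyethyl)phenyl in place of 4-amino-3-methoxyphenyl gives a 10-fold higher number from compound 2 to compound 3 (1.00 log units; beyond the scatter). Setting 1-hydroxyethyl in place of methoxy on an aromatic carbon gives no change at the digits printed from compound 1 to compound 3 (within the scatter), so these two groups cannot be told apart here. Among the three compounds, only the one with 4-amino-3-methoxyphenyl stands apart, and nothing measured here accounts for this.

From the compounds shown here alone, it stays open whether an amine alone, as in 4-aminophenyl, would hold the low number of compound 2 or whether the methoxy is needed with it. Going by these compounds, how a carboxylic acid or a longer chain would read at this place also stays open.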